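Amide Aryl Variation on a Shared Core: Compound 4 Expected

This account rests on a few compounds, and the source may have more. Where it says the series, first, only, none or still open, it means among the compounds named here.

Measured compounds:
compound 1 `CCc1cccc(NC(=O)CSc2nc(Nc3ccccc3)c3ccccc3n2)c1` gives 11000 nM
compound 2 `O=C(CSc1nc(Nc2ccccc2)c2ccccc2n1)Nc1ccc(Cl)cc1` gives 12900 nM
compound 3 `O=C(CSc1nc(Nc2ccccc2)c2ccccc2n1)Nc1ccc(C(F)(F)F)cc1` gives 10400 nM

In a functional assay on PC-3 cells (Homo sapiens) for inhibition, read by MTT assay, with a stated time of 72 h (on this read-out higher numbers stand for weaker inhibition and lower numbers for stronger inhibition), the three numbers sit close together: a 1.2-fold higher number from compound 1 to compound 2 (0.07 log units; within the scatter), a 1.1-fold lower number from compound 1 to compound 3 (0.02 log units; within the scatter), and a 1.2-fold lower number from compound 2 to compound 3 (0.09 log units; within the scatter). Compound 3 stands at the low end of the three, but its gaps to compound 1 and compound 2 are within the scatter, so no ordering can be claimed. Compound 4 `O=C(CSc1nc(Nc2ccccc2)c2ccccc2n1)Nc1ccc(Cl)cc1Cl` differs from compound 3 in one place: 2,4-dichlorophenyl in place of 4-(trifluoromethyl)phenyl on an amide-type nitrogen. Going by the values given here, the steps that bear on this are the three swaps of the aryl group on the amide-type nitrogen already measured, and all stayed within the scatter. Compound 4 is therefore expected to give 11000 nM in this assay, between 5500 nM and 22000 nM. The step this estimate means for compound 4, a 1.1-fold higher number from compound 3 to compound 4 (0.02 log units; within the scatter), is expected to stay within the scatter.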

Compound 4, half-maximal inhibitory concentration: 9110 nM
The estimate for compound 4 lay 1.2-fold (0.08 log units) above the measured number, within the range that was stated.
By their numbers in this assay, from the lowest: compounds 4, 3, 1 and 2 (each within the scatter of the next).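

Adding a chloro to the aromatic ring of compound 2 leaves the number in this assay within the scatter (a 1.4-fold lower number from compound 2 to compound 4 (0.15 log units; within the scatter)), so this position now tolerates a second chlorine without a readable change. The swaps to 2,4-dichlorophenyl on the amide-type nitrogen also stay within the scatter (a 1.1-fold lower number from compound 3 to compound 4 (0.06 log units; within the scatter); a 1.2-fold lower number from compound 1 to compound 4 (0.08 log units; within the scatter)). No evidence here accounts for these small steps.

The compounds shown leave open whether an aryl group carrying an amine or a carboxylic acid would move the number beyond the scatter. The same holds for a longer alkyl chain in place of the aryl group.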